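A few compounds are considered here, and "the series" means these few. Any claim that something is new, unique, unknown or untested is made for them only; others in the source may bear on it.

Compounds measured so far:
compound 1 `COc1ncnc2c1c(-c1cccs1)cn2[C@@H]1O[C@H](CO)[C@@H](O)[C@H]1O` — 13900 nM
compound 2 `CNc1ncnc2c1c(-c1cccs1)cn2[C@@H]1O[C@H](CO)[C@@H](O)[C@H]1O` — > 20000 nM
compound 3 `CSc1ncnc2c1c(-c1cccs1)cn2[C@@H]1O[C@H](CO)[C@@H](O)[C@H]1O` — > 20000 nM

Among the measured compounds shown here, in a functional assay on HepG2 cells (Homo sapiens) for antiproliferative activity, read by XTT assay, with a stated time of 72 h (on this read-out higher numbers stand for weaker inhibition and lower numbers for stronger inhibition), compound 1 gives 13900 nM, the only number in the set. Compound 2 gives > 20000 nM, which is a limit of the assay. Compound 3 gives > 20000 nM, also a limit. For the measured compounds named here, both measured steps, an at least 1.4-fold higher number from compound 1 to compound 2 (0.15 log units; that floor lies within the scatter) and an at least 1.4-fold higher number from compound 1 to compound 3 (0.15 log units; that floor lies within the scatter), alter the methoxy group and are bounded by the limit of > 20000 nM in this assay, at which 2 of the 3 values shown sit; compound 1 therefore stands as the one compound with a readable value. Compound 4 `COc1ncnc2c1c(-c1cc3ccccc3o1)cn2[C@@H]1O[C@H](CO)[C@@H](O)[C@H]1O` changes a different part of the shared core: 1-benzofuran-2-yl in place of thiophen-2-yl on an aromatic carbon. Going by the values given here, no measured step touches this group, so none bears directly on the change, and no direction beyond the scatter can be argued from them. Compound 4 is estimated at 10000 nM, with a range of 2500 nM to 30000 nM, which is an expected step of a 1.4-fold lower number from compound 1 to compound 4 (0.14 log units; within the scatter).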

Compound 4, half-maximal inhibitory concentration: > 20000 nM
Compound 4: no number, only a limit; the forecaster's own chance of this, stated with the estimate: 35%; middle value at least 2.0-fold (0.30 log units) away from the limit.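

In this assay, among the compounds shown here, the first change at this position, away from the methoxy group, gives an at least 1.4-fold higher number from compound 1 to compound 4 (0.15 log units; that floor lies within the scatter). Going by these compounds, compound 4 gives > 20000 nM, which is a limit of the assay, so the added six-membered aromatic ring of carbon only yields no readable value, and the true size of the step stays unknown. With this result, the only readable number remains that of compound 1: the limit of > 20000 nM in this assay, at which 3 of the 4 values shown sit.

On these data alone, whether a phenyl or furan-2-yl group on this aromatic carbon would give a readable value remains open. So does the effect of an unsubstituted amine in place of methoxy.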